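Cyano to nitro on the benzyl ring in a mouse model

The source may hold more compounds than are shown below. What is called first, only, known or untested is meant among the compounds shown, and "the series" means these compounds.

Measured so far:
compound 1 `Cc1ccc(-c2nc3c(C)cccn3c2/C=N/OCc2cn(Cc3ccc(C#N)cc3)nn2)cc1`: 100 mg/kg
compound 2 `Cc1ccc(-c2nc3c(C)cccn3c2/C=N/OCc2cn(Cc3ccc([N+](=O)[O-])cc3)nn2)cc1`: 20 mg/kg
compound 3 `N#Cc1ccc(Cn2cc(CO/N=C/c3c(-c4ccccc4)nc4ccc(Br)cn34)nn2)cc1`: 20 mg/kg

In a functional assay on the whole organism (strain NMRI) with Mus musculus as the target, with a stated time of 4 h (on this read-out lower numbers stand for an effect already at smaller amounts and higher numbers for an effect only at larger amounts of compound), compound 1 gives 100 mg/kg, while compound 2 gives 20 mg/kg. The change between them is nitro in place of cyano on an aromatic carbon, and it brought a 5.0-fold lower number from compound 1 to compound 2 (0.70 log units; beyond the scatter). Compound 3, which carries a different core, gives 20 mg/kg in this assay, level with compound 2 at the digits reported, and the two together stand at the lowest number of the three; the difference between the core of compound 3 and that of compound 1 is not broken down here.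

Compound 4 `O=[N+]([O-])c1ccc(Cn2cc(CO/N=C/c3c(-c4ccccc4)nc4ccc(Br)cn34)nn2)cc1` has not yet been measured in this assay. It differs from compound 3 by nitro in place of cyano on an aromatic carbon, the same change as that from compound 1 to compound 2, made at the same kind of place. Going by the values given here, the step is expected to be a 4.0-fold lower number from compound 3 to compound 4 (0.60 log units; beyond the scatter), resting on the single earlier example a 5.0-fold lower number from compound 1 to compound 2 (0.70 log units; beyond the scatter) and on compound 3 starting from 20 mg/kg. Compound 4 is therefore estimated at 5 mg/kg, with a plausible span from 2 mg/kg to 20 mg/kg.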

Compound 4, minimum effective dose: 40 mg/kg
Compound 4: the middle estimate sits 8.0-fold (0.90 log units) below what was measured, outside the stated range (above it).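

In this assay, placing nitro where cyano stood on the core of compound 3 gave a 2.0-fold higher number from compound 3 to compound 4 (0.30 log units; within the scatter), so on this core the two groups cannot be told apart. The clear drop in the number seen on the core of compound 1 therefore did not carry over, and the two steps disagree: the same change on two cores in this assay, a 5.0-fold lower number (0.70 log units; beyond the scatter) from compound 1 to compound 2 and a 2.0-fold higher number (0.30 log units; within the scatter) from compound 3 to compound 4, 10-fold (1.00 log units) apart, beyond the scatter of two such steps. Going by these compounds alone, this shows that, in this series, the result of the change on one core cannot be assumed for another, but with only one pair on each core it does not show which feature of the cores sets the pairs apart or how a further core would respond.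

The compounds shown leave open how other groups in the same place on the benzyl ring, such as an amine or a carboxylic acid, would fare on either core. They also leave open whether the bromo group of compound 3 or the methyl groups of compound 1 matter most to the difference in outcome.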